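Taking the Chloro Group Off Compound 3

A few compounds are considered here, and "the series" means these few. Any claim that something is new, unique, unknown or untested is made for them only; others in the source may bear on it.

Compound 1 `N#Cc1c(-c2ccccc2)nc2c(c(-c3ccccc3)nn2-c2ccccc2)c1-c1ccc(N2CCCCC2)cc1` gives 27000 nM
Compound 2 `N#Cc1c(-c2ccc(Cl)cc2)nc2c(c(-c3ccccc3)nn2-c2ccccc2)c1-c1ccc(N2CCCCC2)cc1` gives 10600 nM
Compound 3 `CN1CCN(c2ccc(-c3c(C#N)c(-c4ccc(Cl)cc4)nc4c3c(-c3ccccc3)nn4-c3ccccc3)cc2)CC1` gives 2710 nM

All three numbers come from a functional assay on MCF7 cells (Homo sapiens) for inhibition, read by MTT assay, with a stated time of 48 h (on this read-out higher numbers stand for weaker inhibition and lower numbers for stronger inhibition), and compound 3 has the lowest of them. Compound 2 lies nearest to it and compound 1 furthest away, both beyond the usual scatter.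

Compound 4 `CN1CCN(c2ccc(-c3c(C#N)c(-c4ccccc4)nc4c3c(-c3ccccc3)nn4-c3ccccc3)cc2)CC1` has not been measured yet. It differs from compound 3 by a single change hydrogen in place of chloro on an aromatic carbon (hydrogen in place of chloro on an aromatic carbon, para to a large group), which turns 4-chlorophenyl into phenyl.

The closest evidence is the same swap run the other way. The modest step of a 2.5-fold lower number from compound 1 to compound 2 (0.41 log units; beyond the scatter) came with chloro in place of hydrogen. The step of a 3.9-fold lower number from compound 2 to compound 3 (0.59 log units; beyond the scatter), also modest, brought in the 4-methylpiperazin-1-yl group that compound 4 keeps. Among the compounds with values here, only one pair shows the chloro swap, so its carry-over to this series is untested. Reversing that step suggests a modest rise in the number, meaning weaker inhibition. The expected size is a 2.5-fold higher number from compound 3 to compound 4 (0.41 log units; beyond the scatter) (an estimate, in this assay). The estimated value for compound 4 is 6900 nM (expected range 2800 nM to 17000 nM).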

Compound 4, half-maximal inhibitory concentration: 14300 nM
For compound 4 the middle estimate is 2.1-fold (0.32 log units) below the measured one; measured number inside the range.
By their numbers in this assay, from the lowest: compound 3; then compounds 2, 4 and 1 (each within the scatter of the next, the first and the last beyond it).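

In this assay, turning 4-chlorophenyl into phenyl on the compound carrying the 4-methylpiperazin-1-yl group gives a 5.3-fold higher number from compound 3 to compound 4 (0.72 log units; beyond the scatter), so the chloro position also counts on this second core, not only on the core with piperidin-1-yl, and the two chloro steps agree as closely as such measurements can show: the same change on two cores in this assay, a 2.5-fold lower number (0.41 log units; beyond the scatter) from compound 1 to compound 2 and a 5.3-fold lower number (0.72 log units; beyond the scatter) from compound 4 to compound 3, 2.1-fold (0.32 log units) apart, within the scatter of two such steps. Without the chloro, the amine swap gives a 1.9-fold lower number from compound 1 to compound 4 (0.28 log units; within the scatter), so on the phenyl compounds this exchange cannot be told apart from repeat variation, although the same exchange on the 4-chlorophenyl compounds lay beyond the scatter, and the two steps cannot be firmly separated: the same change on two cores in this assay, a 3.9-fold lower number (0.59 log units; beyond the scatter) from compound 2 to compound 3 and a 1.9-fold lower number (0.28 log units; within the scatter) from compound 1 to compound 4, 2.1-fold (0.32 log units) apart, within the scatter of two such steps. Taken together, the four compounds give no firm sign that the effects of the chloro and the amine depend on each other, and compound 3, with both groups, has the lowest number of the set.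

Chloro and hydrogen are the only groups shown at this place, so what bromo, methoxy or a carboxylic acid would do there remains open. All four numbers also come from a single cell assay, which leaves open why the chloro changes the number and whether these steps hold in other cells.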